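The source may hold more compounds than are shown below. What is called first, only, known or untested is meant among the compounds shown, and "the series" means these compounds.

Measured so far:
- compound 1 `Cc1cc(Nc2cc(-c3cccs3)[nH]n2)n2nc(SCc3ccc(Br)cc3)nc2n1` gives 4890 nM
- compound 2 `CCCCCc1c(C)nc2nc(SCc3ccc(Cl)cc3)nn2c1Nc1cc(-c2ccccc2)[nH]n1` gives > 50000 nM as a limit
- compound 3 `Cc1cc(Nc2cc(-c3ccccc3)[nH]n2)n2nc(SCC(=O)c3ccccc3)nc2n1` gives 4450 nM

In a functional assay on PC-9 cells (Homo sapiens) for inhibition, read by MTT assay, with a stated time of 72 h (a higher number here means a weaker inhibitor, a lower number a stronger inhibitor), compound 3 at 4450 nM and compound 1 at 4890 nM lie within the scatter of each other, and only these two give true numbers. Compound 2 reports only a limit, > 50000 nM.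

Next comes compound 4 `Cc1ccc(CSc2nc3nc(C)cc(Nc4cc(-c5ccccc5)[nH]n4)n3n2)cc1`, which differs from compound 3 by 4-methylphenyl in place of benzoyl on a saturated chain carbon bound to a sulfur.

Within the data shown here, no measured step isolates this change. Among the measured compounds shown here, with compound 1 at 4890 nM and compound 3 at 4450 nM as the only numbers, no step beyond the scatter is expected in this assay in either direction. The estimated step of a 1.3-fold higher number from compound 3 to compound 4 (0.13 log units; within the scatter) stays within the scatter. For compound 4 the expected value is 6000 nM, with an estimated range of 2000 nM to 25000 nM.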

Compound 4, half-maximal inhibitory concentration: 7310 nM
The estimate for compound 4 lay 1.2-fold (0.09 log units) below the measured number; the measured number falls inside the stated range.
By their numbers in this assay, from the lowest: compounds 3, 1 and 4 (each within the scatter of the next). At a limit, above all of these: compound 2.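

In this assay, among these compounds, the one readable step at this place, a 1.6-fold higher number from compound 3 to compound 4 (0.22 log units; within the scatter), stays within the scatter. Benzoyl and 4-methylphenyl on a saturated chain carbon bound to a sulfur therefore cannot be told apart here, although only benzoyl carries a carbonyl and a hydrogen-bond acceptor. No measurement shown gives a reason for this step.

On these data alone, whether an amine, a carboxylic acid or a longer chain at this place would give a step beyond the scatter remains open.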